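The source may report more compounds than this note shows. Statements on the series, on what has been measured and on what is new or still open speak of the compounds shown alone.

Measured so far in a functional assay (Pituitary gland cell) with Rattus norvegicus as the target; a higher number here means that more compound is needed for the effect, a lower number that less compound is needed: compound 1 `CC(C)(N)CC(=O)N[C@@H]1CCc2ccccc2N(Cc2ccc(-c3ccccc3S(N)(=O)=O)cc2)C1=O` gives 3 uM; compound 2 `CC(C)(N)CC(=O)N[C@@H]1CCc2ccccc2N(Cc2ccc(-c3ccccc3-c3nnnn3CC(=O)O)cc2)C1=O` gives 1 uM; compound 3 `CC(C)(N)CC(=O)N[C@@H]1CCc2ccccc2N(Cc2ccc(-c3ccccc3S(=O)(=O)NC(=O)c3ccccc3)cc2)C1=O` gives 3 uM.

Compound 3 stands level with compound 1 in this assay, the two together giving the highest numbers of the three, while compound 2 gives the lowest. The step of no change at the digits printed from compound 1 to compound 3 (within the scatter) shows that adding the benzoyl made no difference, whereas a 3.0-fold higher number from compound 2 to compound 3 (0.48 log units; beyond the scatter) and a 3.0-fold lower number from compound 1 to compound 2 (0.48 log units; beyond the scatter) both show a modest advantage for the tetrazolyl-bearing compound 2 over either sulfonamide.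

Compound 4 `Cn1nnc(-c2ccccc2-c2ccc(CN3C(=O)[C@H](NC(=O)CC(C)(C)N)CCc4ccccc43)cc2)n1` differs from compound 3 in one place: 2-methyl-2H-tetrazol-5-yl in place of benzoylsulfamoyl on an aromatic carbon. The two steps that bear on it are those exchanging the sulfonamide groups for a tetrazolyl, each of a modest size in favour of the tetrazolyl. Among the measured compounds shown here, no measured step, however, compares a tetrazolyl carrying a methyl with one carrying a carboxymethyl, so that part of the change rests on nothing measured. For the measured compounds named here, the expectation is therefore a modest lowering, weaker than the one seen for compound 2, namely a 1.5-fold lower number from compound 3 to compound 4 (0.18 log units; within the scatter). For compound 4 the estimated value in this assay is 2 uM, within a range of 0.7 uM to 6 uM.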

Compound 4, concentration for half-maximal effect: 0.3 uM
Compound 4: middle estimate off by 6.7-fold (0.82 log units), on the high side; measured number outside the range, below it.
By their numbers in this assay, from the lowest: compound 4; then compound 2; then compounds 1 and 3 (each within the scatter of the next).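

Among the compounds shown here, on the aromatic carbon ortho to a large group, a 10-fold lower number from compound 3 to compound 4 (1.00 log units; beyond the scatter) and a 10-fold lower number from compound 1 to compound 4 (1.00 log units; beyond the scatter) in this assay are larger than any step among the earlier compounds, so the choice of group at this position can move the number further than those compounds showed. The earlier compounds shown here held only one tetrazole, and a 3.3-fold lower number from compound 2 to compound 4 (0.52 log units; beyond the scatter) now shows that tetrazoles at this position are not interchangeable: the 2-methyl-2H-tetrazol-5-yl and the 1-(carboxymethyl)-1H-tetrazol-5-yl give different numbers, beyond the scatter. Nothing available explains these differences.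

The two tetrazolyl groups differ both in the substituent they carry and in the ring nitrogen that carries it, so the compounds shown leave open how much of the lower number belongs to the methyl and how much to its place on the ring. A 1-methyl-1H-tetrazol-5-yl would separate those two changes, while an unsubstituted tetrazole or a 2-ethyl-2H-tetrazol-5-yl would show whether the methyl is needed at all and whether a longer chain is tolerated.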